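Shortening the Link at the Far End of the Molecule

The compounds below may be only part of what the source reports. "The series", "measured", "known", "first", "only" and "open" are said of these compounds alone.

Compound 1 `CNC(=O)c1cnc(C(=O)CCc2ccc(COc3ccccc3)cc2)o1` carries a methylcarbamoyl group on one end of the shared core and a phenoxymethyl group on the ring at the other end. In an assay for inhibition of Fatty-acid amide hydrolase 1 (Rattus norvegicus) (a higher number here means a weaker inhibitor, a lower number a stronger inhibitor), compound 1 gives 3.6 nM, the second highest of the three measured numbers. Compound 2 `CN(C)C(=O)c1cnc(C(=O)CCc2ccc(COc3ccccc3)cc2)o1` gives 6.7 nM, and the step of a 1.9-fold higher number from compound 1 to compound 2 (0.27 log units; within the scatter) stays within the scatter. Compound 3 `N#Cc1cccc(-c2cnc(C(=O)CCc3ccc(COc4ccccc4)cc3)o2)n1` gives 0.56 nM; the step of a 6.4-fold lower number from compound 1 to compound 3 (0.81 log units; beyond the scatter) is modest but beyond the scatter, and so is a 12-fold lower number from compound 2 to compound 3 (1.08 log units; beyond the scatter). Every one of these measured steps alters the group on the aromatic carbon of the core, while the phenoxymethyl end is kept unchanged throughout. Compound 4 `CNC(=O)c1cnc(C(=O)CCc2ccc(Oc3ccccc3)cc2)o1` differs from compound 1 at that other end instead: phenoxy in place of phenoxymethyl on an aromatic carbon. Going by the values given here, none of the measured steps bears on this part of the molecule, so the data give no direction for the change. The expectation is therefore a step of a 1.4-fold higher number from compound 1 to compound 4 (0.14 log units; within the scatter), within the scatter. Compound 4 is estimated at 5 nM, with a range from 1.5 nM to 16 nM.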

Compound 4, inhibition constant: 11 nM
For compound 4 the middle estimate is 2.2-fold (0.34 log units) below the measured one; low and high end bracket the measured number.
By their numbers in this assay, from the lowest: compound 3; then compounds 1, 2 and 4 (each within the scatter of the next, the first and the last beyond it).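

Going by these compounds alone, the far end of the molecule turns out to matter: in this assay, the step of a 3.1-fold higher number from compound 1 to compound 4 (0.49 log units; beyond the scatter) is the first measured change at this position, and it gives a weaker inhibitor. The change is small, since phenoxy keeps the oxygen and the ring of phenoxymethyl and differs only by the one carbon of the link, with the counts of hydrogen-bond donors and acceptors unchanged. Nothing available explains why this shorter link gives the higher number.

Within the data shown here, with only two link lengths in hand, it remains open whether a longer chain, as in a phenoxyethyl group, would give a stronger or a weaker inhibitor. From the compounds shown here alone, it is also open whether phenoxy in place of phenoxymethyl would have a similar effect alongside the 6-cyanopyridin-2-yl group of compound 3.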